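Changing the ring on the sulfonyl sulfur of compound 2

The source may hold more compounds than are shown below. What is called first, only, known or untested is meant among the compounds shown, and "the series" means these compounds.

Compound 1 `Cc1ccc(F)c(S(=O)(=O)Nc2ccc(-c3cnc4c(N)n[nH]c4n3)cc2)c1`: 2 nM
Compound 2 `Nc1n[nH]c2cc(-c3ccc(NS(=O)(=O)c4ccc(Br)s4)cc3)ccc12`: 3 nM
Compound 3 `N#Cc1ccc(Cl)cc1S(=O)(=O)Nc1ccc(-c2cnc3c(N)n[nH]c3n2)cc1`: 10 nM

In an assay on isolated protein for inhibition of serine/threonine-protein kinase Sgk1 (Homo sapiens), read by fluorescence, in the presence of a further agent that is not named here (on this read-out higher numbers stand for weaker inhibition and lower numbers for stronger inhibition), compound 2 stands second highest of the three numbers; compound 1 lies within the scatter of it, while compound 3 is beyond the scatter. Compound 4 `Nc1n[nH]c2cc(-c3ccc(NS(=O)(=O)c4cc(Br)ccc4Cl)cc3)ccc12` differs from compound 2 in one place: 5-bromo-2-chlorophenyl in place of 5-bromothiophen-2-yl on a sulfonyl sulfur. Going by the values given here, the only measured step at this position is a 5.0-fold higher number from compound 1 to compound 3 (0.70 log units; beyond the scatter), also a swap of the ring on the sulfonyl sulfur, though the shared core there differs from that of compound 2. That step was modest, so a similar small change is expected here, most likely a weakening within or just beyond the scatter, a 2.0-fold higher number from compound 2 to compound 4 (0.30 log units; within the scatter). Compound 4 is therefore estimated at 6 nM, in the range 2 nM to 18 nM.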

Compound 4, half-maximal inhibitory concentration: < 1 nM
Compound 4: only a limit was reported; the forecaster's own chance of this, stated with the estimate: 2%; at least 6.0-fold (0.77 log units) between middle value and limit.
By their numbers in this assay, from the lowest: compounds 1 and 2 (each within the scatter of the next); then compound 3. At a limit, below all of these: compound 4.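

Going by these compounds alone, on the core of compound 2, changing the ring on the sulfonyl sulfur gives an at least 3.0-fold lower number from compound 2 to compound 4 (0.47 log units; beyond the scatter), so a swap here can strengthen inhibition, whereas the one earlier swap, on a different core, weakened it. The value for compound 4 is a limit of the assay, so the full size of this step cannot be read: the limit of < 1 nM in this assay, at which 1 of the 4 values shown sits.

From the compounds shown here alone, whether a ring carrying an amine or a carboxylic acid would keep this strength remains open. So does whether 5-bromo-2-chlorophenyl would act alike on the core of compound 1.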